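Chloro for Hydrogen on the Phenyl Ring

The source may report more compounds than this note shows. Statements on the series, on what has been measured and on what is new or still open speak of the compounds shown alone.

Compound 3 `CCc1nc(-c2cnc3ccc(-c4ccccc4)cc3c2)no1` carries an ethyl group at one end of the shared core and an unsubstituted phenyl at the other. In a functional assay on RD cells (Homo sapiens) for inhibition, read by luminescence and ATP content, with a stated time of 72 h (on this read-out lower numbers stand for higher toxicity in this test and higher numbers for lower toxicity in this test), compound 3 gives > 7400 nM, which is a limit of the test rather than a measured number. Compound 2 `CCc1nc(-c2cnc3ccc(-c4ccc(C)cc4)cc3c2)no1`, which carries a methyl on that phenyl, likewise gives only a limit in this assay, > 7400 nM. The step that the two limits leave unreadable from compound 2 to compound 3 is therefore unreadable in size. Compound 1 `FC(F)(F)c1nc(-c2cnc3ccc(-c4ccc(Cl)cc4)cc3c2)no1`, with a trifluoromethyl in place of the ethyl and a 4-chlorophenyl, gives > 200000 nM in this assay, again a limit. All three values sit at limits: the limit of > 7400 nM in this assay, at which 2 of the 3 values shown sit, and (the limit of > 200000 nM in this assay, at which 1 of the 3 values shown sits).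

Compound 4 `CCc1nc(-c2cnc3ccc(-c4ccc(Cl)cc4)cc3c2)no1` differs from compound 3 by chloro in place of hydrogen on an aromatic carbon. For the measured compounds named here, no measured step covers this change with a readable size; the only hint is that compound 1, which also carries the 4-chlorophenyl, shows nothing up to its limit. The expected step from compound 3 to compound 4 is a step that the limit leaves unreadable from compound 3 to compound 4, that is, none beyond the scatter. Compound 4 is therefore estimated at 20000 nM, within a range from 5000 nM to 200000 nM, and the test will most likely again report only a limit.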

Compound 4, half-maximal cytotoxic concentration: > 22200 nM
Compound 4: a limit, no number (the forecaster's own chance of this, stated with the estimate: 80%); middle value at least 1.1-fold (0.04 log units) away from the limit.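

Compound 4, like compound 1, compound 2 and compound 3, gives only a limit, and none of its steps to those three can be read in size. The compounds shown leave open at what concentration any of them shows toxicity in this assay, and whether going from phenyl to 4-chlorophenyl changes it.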